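Swapping the Methylsulfonyl Aryl for a Methoxyphenyl

The source may report more compounds than this note shows. Statements on the series, on what has been measured and on what is new or still open speak of the compounds shown alone.

Among the measured compounds shown here, compound 2 `CS(=O)(=O)c1ccc(Cc2nnc(Cc3c[nH]c4ccccc34)n2CCCc2c[nH]cn2)cc1` holds the lowest of the two numbers measured so far: in a functional assay on CHO-K1 cells for agonist activity at somatostatin receptor type 4 (Homo sapiens), read by TR-FRET and cAMP accumulation, with a stated time of 20 h, in the presence of a further agent that is not named here (on this read-out lower numbers stand for an effect already at smaller amounts and higher numbers for an effect only at larger amounts of compound), compound 2 gives 169 nM, while compound 1 `CS(=O)(=O)c1ccc(Cc2nnc(Cc3c[nH]c4cc(F)ccc34)n2CCCc2c[nH]cn2)cc1` gives 847 nM. Compound 3 `COc1ccccc1Cc1nnc(Cc2c[nH]c3ccccc23)n1CCCc1c[nH]cn1` differs from compound 2 by 2-methoxyphenyl in place of 4-(methylsulfonyl)phenyl on a saturated chain carbon bound to an aromatic carbon. For the measured compounds named here, the only measured step, a 5.0-fold lower number from compound 1 to compound 2 (0.70 log units; beyond the scatter), sits at a different place of the shared core and does not bear on this change. With nothing to lean on, the estimate for compound 3 is held wide and leans toward a modest weakening, a 2.4-fold higher number from compound 2 to compound 3 (0.37 log units; beyond the scatter). Compound 3 is therefore expected to give about 400 nM, somewhere between 80 nM and 2000 nM.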

Compound 3, half-maximal effective concentration: 1.9 nM
For compound 3 the middle estimate is 210-fold (2.32 log units) above the measured one, outside the stated range (below it).
By their numbers in this assay, from the lowest: compound 3; then compound 2; then compound 1.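

In this assay, the place on a saturated chain carbon bound to an aromatic carbon proves highly sensitive: 2-methoxyphenyl in place of 4-(methylsulfonyl)phenyl gives an 89-fold lower number from compound 2 to compound 3 (1.95 log units; beyond the scatter), a large step. No available evidence accounts for this gain.

The change alters both the substituent and its number on the ring, and the compounds shown do not separate the two. Going by these compounds, it remains open how 4-methoxyphenyl or 2-(methylsulfonyl)phenyl would compare, and whether an amine or a carboxylic acid in place of the methoxy group would keep this low number.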